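From tert-butyl to benzyl at the assay limit

A few compounds are considered here, and "the series" means these few. Any claim that something is new, unique, unknown or untested is made for them only; others in the source may bear on it.

compound 1 `CCOC(=O)/C=C/c1cc(/C=C/[C@](C)(/C=C/c2ccc(OC)cc2)CCC=C(C)C)ccc1O`: > 36600 nM
compound 2 `COc1ccc(/C=C/[C@@](C)(/C=C/c2ccc(O)c(/C=C/C(=O)OC(C)(C)C)c2)CCC=C(C)C)cc1`: > 36600 nM

Both values come from a functional assay on SEM cells (Homo sapiens) for cytotoxicity, with a stated time of 72 h (on this read-out higher numbers stand for an effect only at larger amounts of compound and lower numbers for an effect already at smaller amounts), and neither is a true number. Compound 2 stands at > 36600 nM, which is a limit of the assay. Compound 3 `COc1ccc(/C=C/[C@@](C)(/C=C/c2ccc(O)c(/C=C/C(=O)OCc3ccccc3)c2)CCC=C(C)C)cc1` carries benzyl in place of tert-butyl on an oxygen next to a carbonyl group. Among the compounds with values here, the only measured change at this place is a step that the two limits leave unreadable from compound 1 to compound 2, and its size cannot be read. the limit of > 36600 nM in this assay, at which 2 of the 2 values shown sit, gives no sign of direction, so no clear step is expected. The expected step is an at least 1.0-fold lower number from compound 2 to compound 3 (0.01 log units; that floor lies within the scatter). Compound 3 is estimated at 35000 nM, with an expected range from 10000 nM to 60000 nM.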

Compound 3, half-maximal effective concentration: > 36600 nM
Compound 3 ended at the assay's limit; the forecaster's own chance of this, stated with the estimate: 70%; middle value at least 1.0-fold (0.01 log units) away from the limit.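

No step can be read between compound 1, compound 2 and compound 3, since all three sit at the same assay limit and give no true number: the limit of > 36600 nM in this assay, at which 3 of the 3 values shown sit.

The compounds shown leave open whether ethyl, tert-butyl or benzyl on this oxygen makes any difference to the read-out.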